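Regioisomeric methylbenzyl swap on an inactive anilide acid

This account rests on a few compounds, and the source may have more. Where it says the series, first, only, none or still open, it means among the compounds named here.

The account rests on two measured compounds and one yet to be measured. Compound 1 `COC(=O)[C@H](CCSC)NC(=O)c1ccc(NCc2cncn2Cc2ccc(C)cc2)cc1-c1ccccc1` carries a methyl ester on its amino acid part and a 4-methylbenzyl group on the imidazole. In a functional assay on NIH3T3 cells (Mus musculus) (a lower number here means that less compound is needed, a higher number that more compound is needed for the effect), compound 1 gives only a limit, > 10 uM, and not a number. Compound 2 `CSCC[C@H](NC(=O)c1ccc(NCc2cncn2Cc2cccc(C)c2)cc1-c1ccccc1)C(=O)O` has the free acid and a 3-methylbenzyl group. In this assay compound 2 likewise reaches only a limit, > 10 uM. Where compound 2 stands is therefore fixed by nothing sharper than the limit of > 10 uM in this assay, at which 2 of the 2 values shown sit; both measured values are limits of the same kind, so no ordering between them can be read.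

Compound 3 `CSCC[C@H](NC(=O)c1ccc(NCc2cncn2Cc2ccc(C)cc2)cc1-c1ccccc1)C(=O)O` keeps the free acid of compound 2. The change is 4-methylphenyl in place of 3-methylphenyl on a saturated chain carbon bound to an aromatic nitrogen. For the measured compounds named here, no measured step of this kind is available, and because compound 2 sits at the limit > 10 uM, no direction can be taken from the data. The expected step from compound 2 to compound 3 in this assay is a step that the limit leaves unreadable from compound 2 to compound 3, nothing beyond the scatter. Compound 3 is accordingly estimated at 20 uM, with a range from 5 uM to 80 uM, most likely reported again as a limit.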

Compound 3, concentration for half-maximal effect: > 10 uM
Compound 3: a limit, no number; the forecaster's own chance of this, stated with the estimate: 80%; the middle value is on the limit's open side.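

In this assay compound 3 gives only a limit, > 10 uM. The steps to compound 3 from compound 1 and compound 2 therefore cannot be read, because all three values are limits: the limit of > 10 uM in this assay, at which 3 of the 3 values shown sit.

The compounds shown leave open what concentration any of them needs for the effect, and whether 4-methylbenzyl and 3-methylbenzyl, or methyl ester and free acid, differ at all in this assay.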